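Replacing the basic amide side chain with a propargylic ester

This account rests on a few compounds, and the source may have more. Where it says the series, first, only, none or still open, it means among the compounds named here.

Compound 2 `CCn1c(C(=O)NCCN(C)C)ccc1C(CC)(CC)c1ccc(OCC(O)C(C)(C)C)c(C)c1` carries a (2-(dimethylamino)ethyl)amino group on the carbonyl carbon. In a functional assay on HepG2 cells (Homo sapiens), read by MTT assay, with a stated time of 48 h (a lower number here means a stronger inhibitor, a higher number a weaker inhibitor), compound 2 gives 870 nM, the higher of the two numbers shown; its nearest neighbour, compound 1 `CCn1c(C(=O)NCCN)ccc1C(CC)(CC)c1ccc(OCC(=O)C(C)(C)C)c(C)c1`, gives 180 nM. Compound 3 `CCn1c(C(=O)N(C)CCC#N)ccc1C(CC)(CC)c1ccc(OCC(O)C(C)(C)C)c(C)c1` returns only a limit of this assay, > 50000 nM. Of the three values shown, one sits at the limit of > 50000 nM in this assay, at which 1 of the 3 values shown sits.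

Compound 4 `C#CC(C)OC(=O)c1ccc(C(CC)(CC)c2ccc(OCC(O)C(C)(C)C)c(C)c2)n1CC` differs from compound 2 by (1-methylprop-2-yn-1-yl)oxy in place of (2-(dimethylamino)ethyl)amino on a carbonyl carbon. Within the data shown here, the only measured step that touches this position is an at least 57-fold higher number from compound 2 to compound 3 (1.75 log units; beyond the scatter), and it removed the same (2-(dimethylamino)ethyl)amino group that the change to compound 4 removes. On that single precedent a large step toward a higher number is expected for compound 4, roughly a 23-fold higher number from compound 2 to compound 4 (1.36 log units; beyond the scatter). The estimate for compound 4 in this assay is therefore 20000 nM, with a range from 4000 nM to 60000 nM, and a real chance that only a limit is returned.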

Compound 4, half-maximal inhibitory concentration: > 50000 nM
Compound 4 gave a limit, no number; the forecaster's own chance of this, stated with the estimate: 40%; at least 2.5-fold (0.39 log units) between middle value and limit.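

In this assay, replacing (2-(dimethylamino)ethyl)amino with (1-methylprop-2-yn-1-yl)oxy on the carbonyl carbon gives an at least 57-fold higher number from compound 2 to compound 4 (1.75 log units; beyond the scatter). The loss of activity seen with the (2-cyanoethyl)(methyl)amino group of compound 3 therefore recurs with an entering group that has no nitrogen and is joined through oxygen, so it is not confined to that one amide replacement. Compound 3 and compound 4 both return a limit, and the step between them cannot be read: the limit of > 50000 nM in this assay, at which 2 of the 4 values shown sit.

The compounds shown do not separate the contribution of the terminal dimethylamino group from that of the amide link, as both replacements alter the two together. A longer chain such as (3-(dimethylamino)propyl)amino, or a carboxylic acid on this carbonyl carbon, would test how much of this position can change.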